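This account rests on a few compounds, and the source may have more. Where it says the series, first, only, none or still open, it means among the compounds named here.

Working notes on the series: two compounds have numbers so far in a functional assay on A549 cells (Homo sapiens) for cytotoxicity; a higher number here means a weaker inhibitor, a lower number a stronger inhibitor. Compound 1 `C=C/C=C\[C@H](C)[C@H](OC(N)=O)[C@@H](C)[C@H](O)[C@@H](C)C/C(C)=C\[C@H](C)[C@@H](O)[C@@H](C)/C=C\CCc1ccc(Oc2ccccc2)cc1` gives 10000 nM. Compound 2 `C=C/C=C\[C@H](C)[C@H](OC(N)=O)[C@@H](C)[C@H](O)[C@@H](C)C/C(C)=C\[C@H](C)[C@@H](O)[C@@H](C)/C=C\CCc1cc(F)cc(F)c1` gives 1000 nM, the lower of the two numbers, and its gap to compound 1 lies beyond the scatter.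

Compound 3 `C=C/C=C\[C@H](C)[C@H](OC(N)=O)[C@@H](C)[C@H](O)[C@@H](C)C/C(C)=C\[C@H](C)[C@@H](O)[C@@H](C)/C=C\CCc1ccccc1` has not yet been measured in this assay. Its structural change from compound 2 is phenyl in place of 3,5-difluorophenyl on a saturated chain carbon, two bonds along the chain from a double-bonded chain carbon, with phenyl in place of 3,5-difluorophenyl on a saturated chain carbon, two bonds along the chain from a double-bonded chain carbon. Going by the values given here, no measured pair shows this change alone, so its size remains an expectation anchored on compound 2 at 1000 nM. The expected change, a 2.0-fold higher number from compound 2 to compound 3 (0.30 log units; within the scatter), is a modest rise in the number, toward a weaker inhibitor. Compound 3 is estimated at 2000 nM, with an expected range of 500 nM to 8000 nM.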

Compound 3, half-maximal inhibitory concentration: 510 nM
Beside the measured number, compound 3's estimate is 3.9-fold (0.59 log units) above it; the range from low to high includes it.
By their numbers in this assay, from the lowest: compounds 3 and 2 (each within the scatter of the next); then compound 1.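

In this assay the terminal aromatic ring now has a single-place reading: phenyl in place of 3,5-difluorophenyl gives a 2.0-fold lower number from compound 2 to compound 3 (0.29 log units; within the scatter) and that step lies within the scatter, so the compounds shown do not separate these two groups. Hydrogen in place of phenoxy on an aromatic carbon gives a 20-fold lower number from compound 1 to compound 3 (1.29 log units; beyond the scatter) and this step lies beyond the scatter, which places the large difference in the series on the phenoxy group of compound 1. No data on hand bear on the reason for either step.

Still open, going by these compounds, is where a methoxy or a methyl on that aromatic carbon would fall relative to compound 1 and compound 3. Also open, on these data alone, is how a longer chain before the phenyl, or an amine on the ring, would read in this assay against compound 3.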